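A few compounds are considered here, and "the series" means these few. Any claim that something is new, unique, unknown or untested is made for them only; others in the source may bear on it.

Measured so far:
compound 1, `CC1=CCC2C(CC[C@@]2(C)O)C(C)(C)C1CC[C@@H]1[C@@]2(C)CC[C@@H](O)C(C)(C)O[C@@H]2CC[C@]1(C)O` — 44500 nM
compound 2, `CC1=CC[C@H]2[C@H](CC[C@]2(C)O)C(C)(C)[C@@H]1CC[C@H]1[C@]2(C)CC[C@H](OC(=O)CCC(=O)O)C(C)(C)O[C@H]2CC[C@@]1(C)O` — > 50000 nM
compound 3, `CC1=CC[C@H]2[C@H](CC[C@]2(C)O)C(C)(C)[C@@H]1CC[C@H]1[C@]2(C)CC/C(=N/OCc3ccccc3)C(C)(C)O[C@H]2CC[C@@]1(C)O` — > 50000 nM

In a functional assay on MCF7 cells (Homo sapiens) for antiproliferative activity, read by MTT assay, with a stated time of 72 h (on this read-out lower numbers stand for stronger inhibition and higher numbers for weaker inhibition), compound 1 gives 44500 nM. For compound 2 the result > 50000 nM is a limit of the assay rather than a number. For compound 3 the result > 50000 nM is likewise a limit of the assay. Compound 2 therefore stands at the limit of > 50000 nM in this assay, at which 2 of the 3 values shown sit, together with compound 3, while only compound 1 has a measured number, and that number is itself weak.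

Compound 4, `COc1ccc(C(=O)O[C@H]2CC[C@]3(C)[C@H](CC[C@@](C)(O)[C@H]3CC[C@@H]3C(C)=CC[C@H]4[C@H](CC[C@]4(C)O)C3(C)C)OC2(C)C)cc1`, is taken from compound 2 by one change: 4-methoxyphenyl in place of 2-carboxyethyl on a carbonyl carbon. Among the compounds with values here, no measured pair in this set shows what such a change does, so the expectation rests only on where compound 2 sits. In this assay the step is expected to be small, at most a modest move toward stronger inhibition, and it may well stay within the scatter. Compound 4 is thus estimated at 40000 nM, with a range from 15000 nM to 100000 nM, which would mean a step of an at least 1.2-fold lower number from compound 2 to compound 4 (0.09 log units; that floor lies within the scatter).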

Compound 4, half-maximal inhibitory concentration: 41700 nM
Compound 4: the middle estimate sits 1.0-fold (0.02 log units) below what was measured, within the range that was stated.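

In this assay, compound 4 gives a measured number with 4-methoxyphenyl on this carbonyl carbon, where compound 2, with 2-carboxyethyl there, gave none. The result for compound 2, > 50000 nM, is a limit of the assay and not a number. The change therefore reads only as an at least 1.1-fold lower number from compound 2 to compound 4 (0.07 log units; that floor lies within the scatter), so it shows no gain that clears the scatter, and inhibition in this set stays close to the ceiling of the assay: the limit of > 50000 nM in this assay, at which 2 of the 4 values shown sit.

From the compounds shown here alone, how far compound 2 really lies from compound 4 stays open, so the true size of this step is unknown. Also open, going by these compounds, is whether an amine or a longer chain in place of 4-methoxyphenyl on this carbonyl carbon would bring the number down to a clearly stronger level.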